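This account rests on a few compounds, and the source may have more. Where it says the series, first, only, none or still open, it means among the compounds named here.

Compound 3 `Clc1ccccc1/C=N/c1sc2c(c1-c1nc3ccccc3s1)CCCC2` sits second highest of the three numbers measured in an ADME assay on HeLa cells (Homo sapiens) for cytotoxicity, read by MTT assay, with a stated time of 72 h (a higher number here means that more compound is tolerated, a lower number that less compound is tolerated), where compound 3 gives 407 ug/mL. Its nearest neighbour is compound 2 `Fc1ccccc1/C=N/c1sc2c(c1-c1nc3ccccc3s1)CCCC2`, which in this assay gives 426 ug/mL; the difference, a 1.0-fold lower number from compound 2 to compound 3 (0.02 log units; within the scatter), is within the scatter. Compound 1 `Fc1ccc(/C=N/c2sc3c(c2-c2nc4ccccc4s2)CCCC3)cc1` gives 277 ug/mL in this assay, and both a 1.5-fold higher number from compound 1 to compound 2 (0.19 log units; within the scatter) and a 1.5-fold higher number from compound 1 to compound 3 (0.17 log units; within the scatter) also stay within the scatter. Compound 4 `O=[N+]([O-])c1ccccc1/C=N/c1sc2c(c1-c1nc3ccccc3s1)CCCC2` differs from compound 3 only in that (nitro in place of chloro on an aromatic carbon). Among the compounds with values here, the one swap on an aromatic carbon seen so far, from compound 2 to compound 3, left the number essentially unchanged, so no step beyond the scatter is expected for compound 4 in this assay, that is a 1.1-fold lower number from compound 3 to compound 4 (0.03 log units; within the scatter). Compound 4 is estimated at 380 ug/mL, with a range from 200 ug/mL to 620 ug/mL.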

Compound 4, half-maximal cytotoxic concentration: 369 ug/mL
Beside the measured number, compound 4's estimate is 1.0-fold (0.01 log units) above it; low and high end bracket the measured number.
By their numbers in this assay, from the lowest: compounds 1, 4, 3 and 2 (each within the scatter of the next).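

With a 1.1-fold lower number from compound 3 to compound 4 (0.04 log units; within the scatter) and a 1.2-fold lower number from compound 2 to compound 4 (0.06 log units; within the scatter) and a 1.3-fold higher number from compound 1 to compound 4 (0.12 log units; within the scatter) in this assay, all three new steps stay within the scatter. Within the data shown here, on this aromatic carbon, ortho to a large group, nitro with its 3 heavy atoms and 2 hydrogen-bond acceptors now joins chloro and fluoro with no step beyond the scatter, so the range of groups tried here is wider than the earlier compounds showed, yet the number stays flat. As far as these compounds go, whether an amine or a carboxylic acid on this carbon would give a step beyond the scatter stays open. No evidence is available that bears on these numbers.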